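Compound 4: 4,5-dimethyl-1,3-thiazol-2-yl replaces 2,6-difluorophenyl

The source may hold more compounds than are shown below. What is called first, only, known or untested is meant among the compounds shown, and "the series" means these compounds.

Compound 1, `CC[C@H](C)[C@H](N)CN(C(=O)[C@@H]1C[C@H]1c1ccc(OC)cc1)c1ccc(-c2ccccc2)cc1`: in a functional assay for agonist activity at G protein-coupled receptor 88 (Homo sapiens), read by HTRF and cAMP accumulation (on this read-out lower numbers stand for an effect already at smaller amounts and higher numbers for an effect only at larger amounts of compound), compound 1 reaches only the assay limit > 25000 nM.
Compound 2, `CC[C@H](C)[C@H](N)CN(C(=O)[C@@H]1C[C@H]1c1cccc(C#N)c1)c1ccc(-c2ccccc2)cc1`: compound 2 gives 1600 nM.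
Compound 3, `CC[C@H](C)[C@H](N)CN(C(=O)[C@@H]1C[C@H]1c1c(F)cccc1F)c1ccc(-c2ccccc2)cc1`: compound 3 gives 11000 nM.

Compound 3 holds the highest of the two numbers measured; its nearest neighbour is compound 2, with a 6.9-fold higher number from compound 2 to compound 3 (0.84 log units; beyond the scatter). Compound 4, `CC[C@H](C)[C@H](N)CN(C(=O)[C@@H]1C[C@H]1c1nc(C)c(C)s1)c1ccc(-c2ccccc2)cc1`, differs from compound 3 in one place: 4,5-dimethyl-1,3-thiazol-2-yl in place of 2,6-difluorophenyl on a saturated ring carbon. All three measured steps change the group on that same saturated ring carbon, and they span a wide range: an at least 15-fold lower number from compound 1 to compound 2 (1.19 log units; beyond the scatter), an at least 2.2-fold lower number from compound 1 to compound 3 (0.35 log units; beyond the scatter) and a 6.9-fold higher number from compound 2 to compound 3 (0.84 log units; beyond the scatter). None of them exchanges a six-membered carbon ring for a five-membered ring with hetero atoms, so the direction for compound 4 is open. Compound 4 is therefore estimated at 4000 nM, with a broad range of 600 nM to 25000 nM, meaning an expected 2.8-fold lower number from compound 3 to compound 4 (0.44 log units; beyond the scatter).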

Compound 4, half-maximal effective concentration: 3600 nM
Compound 4: middle estimate off by 1.1-fold (0.05 log units), on the high side; the range from low to high includes it.
By their numbers in this assay, from the lowest: compound 2; then compound 4; then compound 3. At a limit, above all of these: compound 1.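

In this assay, the group on this saturated ring carbon need not be a six-membered aromatic ring of carbon only: 4,5-dimethyl-1,3-thiazol-2-yl gives a 3.1-fold lower number from compound 3 to compound 4 (0.49 log units; beyond the scatter), though still a 2.3-fold higher number from compound 2 to compound 4 (0.35 log units; beyond the scatter). Against the 4-methoxyphenyl group, the change gives an at least 6.9-fold lower number from compound 1 to compound 4 (0.84 log units; beyond the scatter). That step rests on a value that is only a limit for compound 1: the limit of > 25000 nM in this assay, at which 1 of the 4 values shown sits.

From the compounds shown here alone, whether the two methyl groups of the 4,5-dimethyl-1,3-thiazol-2-yl group contribute to this result stays open. So does the effect of an amine or a carboxylic acid on that ring.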